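A few compounds are considered here, and "the series" means these few. Any claim that something is new, unique, unknown or untested is made for them only; others in the source may bear on it.

Compound 1 `O=C(c1ccc(C(F)(F)F)c(F)c1)c1ccc2nc(NC(=O)C(F)(F)F)cn2c1`: 56.5%
Compound 2 `Cc1ccc(F)c(C(=O)c2ccc3nc(NC(=O)C(F)(F)F)cn3c2)c1`: 66.3%

Both values come from a functional assay on MCF7 cells (Homo sapiens) for inhibition, read by sulforhodamine B assay, with a stated time of 48 h, tested at 50 uM (a higher number here means more inhibition of growth at the concentration tested, a lower number less inhibition of growth), which measures how far a compound holds back the growth of a cancer cell line. Compound 2 stands level with compound 1: the gap between their two numbers lies within the scatter of repeated measurements, so the data do not rank them. For the measured compounds named here, these are the only two numbers available so far.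

The next compound is compound 3 `Cc1ccc(C(=O)c2ccc3nc(NC(=O)C(F)(F)F)cn3c2)cc1F`, which has the same atoms as compound 2, joined differently. It carries 3-fluoro-4-methylphenyl in place of 2-fluoro-5-methylphenyl on a carbonyl carbon.

Going by the values given here, no pair of measured compounds shows what a single change of this kind does, so any forecast here is rough. Compound 1 gives 56.5% and compound 2 gives 66.3%, and these values sit close together despite the different groups they carry. On that basis, the expected change, a number 4.3 percentage points lower from compound 2 to compound 3 (within the scatter), is an estimate of no shift beyond the scatter, in either direction. For compound 3 the expected value is 62%, with an estimated range from 47% to 76%.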

Compound 3, percent growth inhibition at one concentration: 57.3%
For compound 3 the middle estimate is 4.7 percentage points above the measured one, within the range that was stated.
By their numbers in this assay, from the lowest: compounds 1, 3 and 2 (each within the scatter of the next).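

In this assay, the 3-fluoro-4-methylphenyl in place of 2-fluoro-5-methylphenyl on the carbonyl carbon gives a number 9 percentage points lower from compound 2 to compound 3 (within the scatter) and so shows that this rearrangement of the same atoms produces no shift that can be told apart from the scatter. Compound 3 also provides a second single change, methyl in place of trifluoromethyl on an aromatic carbon, which gives a number 0.8 percentage points higher from compound 1 to compound 3 (within the scatter) and so leaves these two groups indistinguishable at this place in this test. Nothing measured here bears on why these compounds give such closely matched numbers.

These compounds leave open whether a group of a different kind on the ring, such as an amine or a carboxylic acid, would move the number beyond the scatter. As far as these compounds go, all three readings also come from one tested concentration, so how growth inhibition changes as the concentration rises or falls remains open too.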